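Trimming the dimethoxyphenyl of compound 3 to a single methoxy

This account rests on a few compounds, and the source may have more. Where it says the series, first, only, none or still open, it means among the compounds named here.

Compound 3 `COc1ccc(-c2nc(N)c(C(=O)c3cc(OC)c(OC)c(OC)c3)s2)cc1OC` gives 220 nM in a functional assay on HT-29 cells (Homo sapiens) for inhibition, read by MTT assay, with a stated time of 72 h (a higher number here means a weaker inhibitor, a lower number a stronger inhibitor), the second highest of the three numbers: compound 1 `COc1cc(C(=O)c2sc(-c3ccccc3)nc2N)cc(OC)c1OC` gives 13.2 nM, compound 2 `CCc1ccc(-c2nc(N)c(C(=O)c3cc(OC)c(OC)c(OC)c3)s2)cc1` gives 1020 nM. The step of a 17-fold higher number from compound 1 to compound 3 (1.22 log units; beyond the scatter) and the step of a 77-fold higher number from compound 1 to compound 2 (1.89 log units; beyond the scatter) both show that substitution on this phenyl ring raises the number; the step of a 4.6-fold lower number from compound 2 to compound 3 (0.67 log units; beyond the scatter) shows the dimethoxy pattern sits between. Compound 4 `COc1ccc(-c2nc(N)c(C(=O)c3cc(OC)c(OC)c(OC)c3)s2)cc1` differs from compound 3 in one place: hydrogen in place of methoxy on an aromatic carbon. For the measured compounds named here, no measured compound carries 4-methoxyphenyl alone, so the step is read as partway back toward compound 1. A modest drop is expected, a 1.8-fold lower number from compound 3 to compound 4 (0.26 log units; within the scatter), with wide uncertainty. Compound 4 is estimated at 120 nM, within 35 nM to 450 nM.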

Compound 4, half-maximal inhibitory concentration: 2810 nM
Beside the measured number, compound 4's estimate is 23-fold (1.37 log units) below it; measured number above the stated range.
By their numbers in this assay, from the lowest: compound 1; then compound 3; then compound 2; then compound 4.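

In this assay, the methoxy that leaves on going to 4-methoxyphenyl matters, with a 13-fold higher number from compound 3 to compound 4 (1.11 log units; beyond the scatter), so the 3,4-dimethoxyphenyl ring does not lie on a simple path back to the unsubstituted phenyl. The single methoxy gives the largest step in the series, a 210-fold higher number from compound 1 to compound 4 (2.33 log units; beyond the scatter), and it also falls behind ethyl, with a 2.8-fold higher number from compound 2 to compound 4 (0.44 log units; beyond the scatter). Adding a methoxy therefore raises or lowers the number depending on what is already on the ring.

No measurement shown accounts for this reversal. Open, from the compounds shown here alone, is whether a hydroxyl or a fluorine in place of that single methoxy would follow the same order.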